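From Isopropyl to Cyclopropyl on a Shared Core

This account rests on a few compounds, and the source may have more. Where it says the series, first, only, none or still open, it means among the compounds named here.

Among the compounds with values here, in a functional assay on MCF7 cells (Homo sapiens) for antiproliferative activity, read by MTT assay, with a stated time of 72 h (on this read-out higher numbers stand for weaker inhibition and lower numbers for stronger inhibition), compound 1 `CC(C)N1C(=O)COc2ccc(-c3cnc(Cl)c(NS(=O)(=O)c4ccc(F)cc4)c3)cc21` gives 26600 nM, the only true number among the three compounds tested so far. Compound 2 `COc1cccc(N2C(=O)COc3ccc(-c4cccc(NS(=O)(=O)c5ccc(F)cc5)c4)cc32)c1` gives only a limit, > 40000 nM, not a number. Compound 3 `Cc1ccc(N2C(=O)COc3ccc(-c4cnc5ccccc5c4)cc32)cc1` also gives only a limit, > 40000 nM.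

Compound 4 `O=C1COc2ccc(-c3cnc(Cl)c(NS(=O)(=O)c4ccc(F)cc4)c3)cc2N1C1CC1` keeps the core of compound 1 but has cyclopropyl in place of isopropyl on an amide-type nitrogen in a ring. Both groups have the same count of heavy atoms, and the new one closes a ring. Within the data shown here, no two measured compounds differ in just one place, so no measured step can serve as a guide. Among the measured compounds shown here, the only anchor is compound 1 at 26600 nM. In this assay, the swap is therefore expected to cause no step beyond the usual scatter, in either direction. The expected change is a 1.0-fold lower number from compound 1 to compound 4 (0.01 log units; within the scatter). Compound 4 is estimated at 26000 nM, with an expected range from 12000 nM to 50000 nM.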

Compound 4, half-maximal inhibitory concentration: 16700 nM
The estimate for compound 4 lay 1.6-fold (0.19 log units) above the measured number; the measured number falls inside the stated range.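

Within the data shown here, this is the first step in the set that changes one place only: in this assay, replacing isopropyl with cyclopropyl on the amide-type nitrogen gives a 1.6-fold lower number from compound 1 to compound 4 (0.20 log units; within the scatter). At this position, then, closing a three-membered ring without changing the count of heavy atoms leaves the read-out within what repeat measurements would show, so this change neither clearly helps nor clearly harms. Any gain or loss from other changes would also have to be read on a scale whose upper end gives a limit and not a number: the limit of > 40000 nM in this assay, at which 2 of the 4 values shown sit.

Compound 2 and compound 3 differ from compound 1 in more than one place, so their steps cannot be read and they do not show how other groups behave on this nitrogen. Going by these compounds, whether a longer chain such as n-butyl, or a chain ending in an amine, would move the number beyond the scatter remains open.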